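Working notes: from compound 1 to compound 4

This account rests on a few compounds, and the source may have more. Where it says the series, first, only, none or still open, it means among the compounds named here.

In a physicochemical assay for solubility, measured as kinetic solubility, at pH 2 (a lower number here means a less soluble compound, a higher number a more soluble compound), compound 1 `CC(C)C(c1ccc(-c2ccc3cccc(F)c3c2)[nH]c1=O)C1SC(=O)NC1=O` gives 11300 nM. Compound 3 `CCn1ncc2c(F)cc(-c3ccc(C(/C=C4\OC(=O)NC4=O)(CC)CC)c(=O)[nH]3)cc21` gives 21700 nM, within the scatter of compound 1. Compound 2 `O=C1NC(=O)/C(=C/C2(c3ccc(-c4ccc5cccc(F)c5c4)[nH]c3=O)CCCC2)O1` gives 2550 nM, a lower number than compound 1 and beyond the scatter. Compound 1 therefore stands level with compound 3 and clear of compound 2.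

Compound 4 `CC(C)C(/C=C1/C(=O)NC(=O)N1C)c1ccc(-c2ccc3cccc(F)c3c2)[nH]c1=O` differs from compound 1 by a group of 9 heavy atoms (5 carbon, 2 nitrogen, 2 oxygen; one five-membered non-aromatic ring with 2 hetero atoms) in place of a group of 7 heavy atoms (3 carbon, 1 nitrogen, 2 oxygen, 1 sulfur; one five-membered non-aromatic ring with 2 hetero atoms), on a saturated chain carbon bound to an aromatic carbon and a saturated chain carbon. For the measured compounds named here, no measured pair isolates this change, so the expectation rests on indirect evidence. Compound 2 at 2550 nM resembles compound 4 in carrying its five-membered non-aromatic ring on a chain double bond, and it shares the aromatic end of compound 1. This points to a lower number. Compound 3 at 21700 nM has the same ring linkage on a different core and goes against that reading. The expected step of a 1.9-fold lower number from compound 1 to compound 4 (0.27 log units; within the scatter) is therefore modest and towards a lower number, close to the scatter. Compound 4 is estimated at 6000 nM, with an expected range of 1800 nM to 18000 nM.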

Compound 4, solubility: 8300 nM
Beside the measured number, compound 4's estimate is 1.4-fold (0.14 log units) below it; the measured number falls inside the stated range.
By their numbers in this assay, from the lowest: compound 2; then compounds 4, 1 and 3 (each within the scatter of the next, the first and the last beyond it).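

In this assay, for the compounds shown here, the step of a 1.4-fold lower number from compound 1 to compound 4 (0.13 log units; within the scatter) is the first reading of a single change; the earlier compounds offered no pair differing in one place. On the saturated chain carbon bound to an aromatic carbon and a saturated chain carbon, 2,4-dioxo-1,3-thiazolidin-5-yl can thus give way to the group of 9 heavy atoms, which carries no sulfur and has 3 double bonds outside aromatic rings, without a difference that stands clear of the scatter. Nothing measured here offers an explanation for this result.

A single step cannot separate the loss of sulfur from the other differences between the two groups. On these data alone, whether an amine or a carboxylic acid on this same carbon would give a step beyond the scatter remains open, as does whether the entering group would behave alike on another core.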